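Swapping a Ring for an Open Chain at the Sulfonyl

The source may report more compounds than this note shows. Statements on the series, on what has been measured and on what is new or still open speak of the compounds shown alone.

Two compounds share one core and differ only in the group at the end of the chain that carries the sulfonyl. Compound 1 `O=S(=O)(/C=C/c1ccc(O)c(O)c1)CCC1CCCCC1` was tested in a functional assay, read by fluorescence and spectrophotometry, with a stated time of 1 h (a higher number here means that more compound is needed for the effect, a lower number that less compound is needed), and gives 9800 nM. Compound 2 `O=S(=O)(/C=C/c1ccc(O)c(O)c1)CCCCCCCCCO` in this assay gives 7500 nM. Compound 1 has the highest of the two numbers, yet its gap to compound 2 lies within the scatter, so the two cannot be told apart. Compound 3 `C=CCCCCCS(=O)(=O)/C=C/c1ccc(O)c(O)c1` has not yet been measured. It differs from compound 1 in one place: pent-4-en-1-yl in place of cyclohexyl on a saturated chain carbon, two bonds along the chain from a sulfonyl sulfur. Among the measured compounds shown here, with only two measured compounds and no measured step, the single comparison available shows two quite different chain ends giving numbers within the scatter of each other, which suggests this end of the molecule does not move the read-out much. In this assay the expected step is a 1.2-fold lower number from compound 1 to compound 3 (0.06 log units; within the scatter), none beyond the scatter. Compound 3 is therefore estimated at 8500 nM in this assay, with a range from 3500 nM to 20000 nM.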

Compound 3, half-maximal effective concentration: 7100 nM
Estimate against measurement, compound 3: 1.2-fold (0.08 log units) above; low and high end bracket the measured number.
By their numbers in this assay, from the lowest: compounds 3, 2 and 1 (each within the scatter of the next).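

In this assay, pent-4-en-1-yl in place of cyclohexyl gives a 1.4-fold lower number from compound 1 to compound 3 (0.14 log units; within the scatter) and so shows that, at this place on the chain, a ring and an open chain ending in a double bond cannot be told apart. The second change, vinyl in place of 4-hydroxybutyl, gives a 1.1-fold lower number from compound 2 to compound 3 (0.02 log units; within the scatter) and so shows that a chain ending in a double bond and one ending in a hydroxyl group cannot be told apart here either, which turns the earlier single comparison into two measured steps. Nothing measured here bears on why these chain ends give such similar numbers.

Still open, on these data alone, is whether a chain end of another kind, such as an amine or a carboxylic acid, would move the number beyond the scatter. As far as these compounds go, a phenyl ring in place of cyclohexyl, or a much shorter chain such as ethyl, remains equally open.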